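A few compounds are considered here, and "the series" means these few. Any claim that something is new, unique, unknown or untested is made for them only; others in the source may bear on it.

Measured compounds:
- compound 1, `COc1ccc2c(=O)c(/C=C/C(=O)Nc3cc(C)ccc3C)coc2c1`: 11100 nM
- compound 2, `COc1ccc2c(=O)c(/C=C/C(=O)NCc3cccc(F)c3)coc2c1`: 10100 nM
- compound 3, `COc1ccc2c(=O)c(/C=C/C(=O)NCc3ccc(C)cc3)coc2c1`: 14300 nM

In a functional assay on Huh-7 cells (Homo sapiens) for inhibition, read by MTT assay, with a stated time of 48 h (a higher number here means a weaker inhibitor, a lower number a stronger inhibitor), the three numbers sit close together. Compound 3 gives the highest of them, but the steps that reach it, a 1.3-fold higher number from compound 1 to compound 3 (0.11 log units; within the scatter) and a 1.4-fold higher number from compound 2 to compound 3 (0.15 log units; within the scatter), are both within the scatter, so nothing separates it from compound 1 or compound 2 on this assay.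

Compound 4, `COc1ccc2c(=O)c(/C=C/C(=O)Nc3ccc(C)cc3)coc2c1`, is not yet measured. The change from compound 3 is 4-methylphenyl in place of 4-methylbenzyl on an amide-type nitrogen. Within the data shown here, no measured step tests exactly this change, but the steps that bear on it are those that swap an aryl group directly on the amide nitrogen for a benzyl group there: a 1.1-fold lower number from compound 1 to compound 2 (0.04 log units; within the scatter) and a 1.3-fold higher number from compound 1 to compound 3 (0.11 log units; within the scatter), both within the scatter. The shared core with an anilide and with the two benzylamides therefore gives the same kind of number in this assay. For compound 4 the expected step is a 1.2-fold lower number from compound 3 to compound 4 (0.08 log units; within the scatter), that is, none beyond the scatter. Compound 4 is accordingly estimated at 12000 nM, with a range from 6000 nM to 25000 nM.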

Compound 4, half-maximal inhibitory concentration: > 100000 nM
Compound 4 ended at the assay's limit; the forecaster's own chance of this, stated with the estimate: 5%; at least 8.3-fold (0.92 log units) between middle value and limit.
By their numbers in this assay, from the lowest: compounds 2, 1 and 3 (each within the scatter of the next). At a limit, above all of these: compound 4.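

In this assay compound 4 gives > 100000 nM, which is a limit of the assay and not a number: the limit of > 100000 nM in this assay, at which 1 of the 4 values shown sits.

Among these compounds, at the amide-type nitrogen, this is the first change to read beyond the scatter, with an at least 6.9-fold higher number from compound 3 to compound 4 (0.84 log units; beyond the scatter) and an at least 9.9-fold higher number from compound 2 to compound 4 (0.99 log units; beyond the scatter). An aryl group directly on that nitrogen does not by itself give this result, since compound 1 also carries one and goes against such a pattern, with an at least 9.0-fold higher number from compound 1 to compound 4 (0.95 log units; beyond the scatter).

On these data alone, how far compound 4 lies past its limit remains open. As far as these compounds go, it is also open whether the gap follows the 4-methylphenyl group specifically, which a plain phenyl or a chlorophenyl group on the same nitrogen would test.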